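Swapping a tetrazolylsulfanyl arm for an ethylpiperazine

The compounds below may be only part of what the source reports. "The series", "measured", "known", "first", "only" and "open" are said of these compounds alone.

Two measured compounds share one core and differ only in the group on a sulfur. Compound 1 `Cn1c(-c2ccc(NC(=O)CSc3nc4ccccc4o3)cc2)nc(-c2ccccc2)c1-c1ccccc1` carries a 1,3-benzoxazol-2-yl there, and in a functional assay on HT-29 cells (Homo sapiens) for cytotoxicity, read by MTT assay, with a stated time of 24 h, tested at 1.6 ug/mL (a higher number here means a stronger effect of the compound at the concentration tested, a lower number a weaker effect), compound 1 gives 41%. Compound 2 `Cn1nnnc1SCC(=O)Nc1ccc(-c2nc(-c3ccccc3)c(-c3ccccc3)n2C)cc1` carries a 1-methyl-1H-tetrazol-5-yl instead, and in this assay compound 2 gives 49.8%. The one measured step, a number 8.8 percentage points higher from compound 1 to compound 2 (within the scatter), is within the scatter, so on the numbers shown compound 2 and compound 1 stand at much the same level, and the data support no order between them.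

Compound 3 `CCN1CCN(CC(=O)Nc2ccc(-c3nc(-c4ccccc4)c(-c4ccccc4)n3C)cc2)CC1` has not yet been measured. It differs from compound 2 as follows: 4-ethylpiperazin-1-yl in place of (1-methyl-1H-tetrazol-5-yl)sulfanyl on a saturated chain carbon bound to a carbonyl carbon. Among the compounds with values here, the only measured step that bears on this is the exchange on a sulfur, a number 8.8 percentage points higher from compound 1 to compound 2 (within the scatter), which left the read-out unmoved beyond the scatter. The change to compound 3 goes further, since the sulfanyl group itself leaves, and nothing measured covers a 4-ethylpiperazin-1-yl in this place. The expected step is a number 4.8 percentage points lower from compound 2 to compound 3 (within the scatter), that is, none beyond the scatter. Compound 3 is therefore estimated at 45%, within 22% to 68%.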

Compound 3, a percentage reported as activity, at one concentration (the size of the read-out at that concentration, not a potency): 13.9%
Compound 3: middle estimate off by 31.1 percentage points, on the high side, outside the stated range (below it).
By their numbers in this assay, from the lowest: compound 3; then compounds 1 and 2 (each within the scatter of the next).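

In this assay, replacing the whole sulfanyl arm moves the read-out where exchanging the ring on the sulfur did not: 4-ethylpiperazin-1-yl in place of (1-methyl-1H-tetrazol-5-yl)sulfanyl gives a number 35.9 percentage points lower from compound 2 to compound 3 (beyond the scatter) and in place of (1,3-benzoxazol-2-yl)sulfanyl gives a number 27.1 percentage points lower from compound 1 to compound 3 (beyond the scatter) on the same shared core. This place, on a saturated chain carbon bound to a carbonyl carbon, therefore responds to what it carries, which the two sulfur-linked compounds, within the scatter of each other, could not show. The data shown give no measured account of why the read-out falls with this change.

Going by these compounds, the step removes the sulfur and the five-membered aromatic ring and brings in the six-membered non-aromatic ring all at once, so it remains open which of these changes goes with the lower read-out. On these data alone, a morpholin-4-yl or a diethylamino group in this place, or a phenylsulfanyl arm that keeps the sulfur, would help to separate these changes, and the ethyl group on the piperazine remains untested against a methyl group or a hydrogen.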